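The compounds below may be only part of what the source reports. "The series", "measured", "known", "first", "only" and "open" are said of these compounds alone.

Compound 1 `CN1CCN(c2ccc(Nc3cc(-c4c[nH]c5ccccc45)ncn3)cc2)CC1`: 49 uL/min
Compound 2 `COc1cc(N2CCN(C)CC2)ccc1Nc1nccc(-c2cn(C)c3c(C)nccc23)n1`: 6 uL/min
Compound 3 `Cn1cc(-c2ccnc(-c3ccc(S(C)(=O)=O)cc3)n2)c2ccncc21`: 8 uL/min

In an ADME assay on cells (Hepatocyte, Rattus norvegicus, strain Wistar Han) for metabolic stability (on this read-out higher numbers stand for fast clearance and lower numbers for slow clearance), compound 2 gives the lowest of the three numbers, though compound 3 sits so close that the two cannot be told apart within the usual scatter of such measurements. Compound 1 lies well beyond that scatter, with much faster clearance. Compound 4 `COc1cc(N2CCN(C)CC2)ccc1Nc1nccc(-c2c[nH]c3c(C)nccc23)n1` has not yet been measured in this assay. It differs from compound 2 in one place: hydrogen in place of methyl on an aromatic nitrogen. For the measured compounds named here, no measured pair differs in just this way, so the size of the step cannot be read from the data. A small step, leaning toward faster clearance but likely within the scatter, is expected, a 1.5-fold higher number from compound 2 to compound 4 (0.18 log units; within the scatter). For compound 4 a value of about 9 uL/min is estimated, with a range from 4 uL/min to 25 uL/min.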

Compound 4, intrinsic clearance in a liver preparation (reported as CLH), per the amount of preparation that the assay uses: < 5 uL/min
Compound 4: no number, only a limit; the forecaster's own chance of this, stated with the estimate: 5%; middle value at least 1.8-fold (0.25 log units) away from the limit.
By their numbers in this assay, from the lowest: compounds 2 and 3 (each within the scatter of the next); then compound 1. At a limit, below all of these: compound 4.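

In this assay, hydrogen in place of methyl on an aromatic nitrogen gives an at least 1.2-fold lower number from compound 2 to compound 4 (0.07 log units; that floor lies within the scatter). The methyl on this nitrogen is therefore not needed to keep clearance slow here, though the step shows no firm drop either. Compound 4 stands at a limit rather than at a number: the limit of < 5 uL/min in this assay, at which 1 of the 4 values shown sits.

On these data alone, the true size of this step stays open, since a limit cannot fix it. Also open, as far as these compounds go, is how an ethyl group or a longer chain on this same nitrogen would behave.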